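The source may report more compounds than this note shows. Statements on the series, on what has been measured and on what is new or still open speak of the compounds shown alone.

Measured compounds:
- Compound 1, `Oc1ccc(-c2cc(-c3ccccc3)nc(-c3ccccc3Cl)c2)cc1`: 2800 nM
- Compound 2, `Oc1ccc(-c2cc(-c3ccccn3)nc(-c3ccccc3Cl)c2)cc1`: "not determined" (no result reported)
- Compound 3, `Oc1ccc(-c2cc(-c3ccncc3)nc(-c3ccccc3Cl)c2)cc1`: "not determined" (no result reported)

For the measured compounds named here, all three were set up for a functional assay on DU-145 cells (Homo sapiens) for cytotoxicity, read by CCK-8 assay and cell counting, with a stated time of 2 days (a lower number here means a stronger inhibitor, a higher number a weaker inhibitor), but compound 1 is the only one for which a number came back. In this assay compound 1 gives 2800 nM. For compound 2 and compound 3 no result was reported, so compound 1 cannot be ranked against them; it simply stands as the single measured point of the set.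

The unmeasured compound 4, `Oc1ccc(-c2cc(-c3ccccc3)nc(-c3cccc(Cl)c3)c2)cc1`, keeps every atom of compound 1 and differs only in how the chlorine sits on the chlorophenyl group: 3-chlorophenyl in place of 2-chlorophenyl on an aromatic carbon. Going by the values given here, nothing among the measured compounds shows what such a rearrangement does, since no pair of measured compounds differs in this way. With one number as the sole anchor, the step from compound 1 to compound 4 is expected to stay within the usual scatter, with no clear direction: a 1.1-fold lower number from compound 1 to compound 4 (0.05 log units; within the scatter). Compound 4 is therefore estimated to give about 2500 nM in this assay, within a range from 800 nM to 8000 nM.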

Compound 4, half-maximal inhibitory concentration: 5360 nM
For compound 4 the middle estimate is 2.1-fold (0.33 log units) below the measured one, and the stated range covers the measured number.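

For the compounds shown here, the first measured step at this position reads a 1.9-fold higher number from compound 1 to compound 4 (0.28 log units; within the scatter) in this assay and so stays inside the normal noise of the test. Swapping 2-chlorophenyl for 3-chlorophenyl on the aromatic carbon next to the ring nitrogen therefore gives two compounds that this test cannot tell apart, and compound 1 and compound 4 are best read as equal here. No other measurement bears on this result.

The compounds shown keep chlorine as the only substituent on this ring, so it remains open what a fluorine, a methoxy group or an amine would do there. Also open, from the compounds shown here alone, is whether a change at this position can move the number beyond the scatter at all, since this single step cannot settle that.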